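Amide variation in the catechol sulfonamide series: compound 4

The source may hold more compounds than are shown below. What is called first, only, known or untested is meant among the compounds shown, and "the series" means these compounds.

Three compounds have numbers in an ADME assay on NCI-H630 cells (Homo sapiens) for cytotoxicity, read by MTT assay, with a stated time of 72 h (a higher number here means that more compound is tolerated, a lower number that less compound is tolerated), so far. Compound 1 `O=C(O)c1c(O)cccc1OCc1ccc2ccccc2c1` reaches only the limit of the assay, > 40000 nM, and so gives no number; this is the limit noted as the limit of > 40000 nM in this assay, at which 1 of the 3 values shown sits. Compound 2 `O=C(NCc1ccc(F)cc1)c1cc(S(=O)(=O)N2CCCCC2)cc(O)c1O` gives 13000 nM in this assay, and compound 3 `O=C(NCc1ccco1)c1cc(S(=O)(=O)N2CCCCC2)cc(O)c1O` gives 33000 nM. Within the data shown here, the one measured step between comparable structures, a 2.5-fold higher number from compound 2 to compound 3 (0.40 log units; beyond the scatter), puts compound 3 at the highest of the two numbers in this assay, with compound 2 the nearest neighbour.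

Compound 4 `O=C(NCC1CCCCC1)c1cc(S(=O)(=O)N2CCCCC2)cc(O)c1O` is the next member and differs from compound 3 only at the amide end: cyclohexyl in place of furan-2-yl on a saturated chain carbon bound to an amide-type nitrogen. Among the measured compounds shown here, no measured step covers a cyclohexyl at this place; the only step at the same position, a 2.5-fold higher number from compound 2 to compound 3 (0.40 log units; beyond the scatter), was modest and went upward from one ring to another. With no closer guide, the step of a 1.3-fold lower number from compound 3 to compound 4 (0.12 log units; within the scatter) is expected to stay within or near the scatter. Compound 4 is therefore estimated at 25000 nM in this assay, within the range 10000 nM to 60000 nM.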

Compound 4, half-maximal cytotoxic concentration: > 40000 nM
Compound 4: a limit, no number; the forecaster's own chance of this, stated with the estimate: 25%; middle value at least 1.6-fold (0.20 log units) away from the limit.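

At the amide end, cyclohexyl is the first group in this series to reach the limit of this assay, so compound 4 has a limit and not a number: the limit of > 40000 nM in this assay, at which 2 of the 4 values shown sit.

Measured against furan-2-yl, the change gives an at least 1.2-fold higher number from compound 3 to compound 4 (0.08 log units; that floor lies within the scatter), which settles no order between these two groups. Measured against 4-fluorophenyl, it gives an at least 3.0-fold higher number from compound 2 to compound 4 (0.48 log units; beyond the scatter), so of the three amides compared at this place, the 4-fluorophenyl group gives the lowest number, and a non-aromatic ring of carbon only is tolerated at least as well as the furan-2-yl ring.

On these data alone, the value of compound 4 therefore stays open, and with it any real difference between the cyclohexyl and furan-2-yl groups. As far as these compounds go, it is also open how an amine, a carboxylic acid or a longer chain would read at this place.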